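Hydrazone aryl swap: fluorophenyl to dichlorohydroxyphenyl

The source may hold more compounds than are shown below. What is called first, only, known or untested is meant among the compounds shown, and "the series" means these compounds.

Compound 1, `O=C(CSc1nnc(-c2ccncc2)o1)N/N=C/c1ccc(O)cc1`, gives 11700 nM in a functional assay on MCF7 cells (Homo sapiens) for cytotoxicity, read by MTT assay, with a stated time of 48 h; on this read-out higher numbers stand for weaker inhibition and lower numbers for stronger inhibition.
Compound 2, `COc1ccc(/C=N/NC(=O)CSc2nnc(-c3ccncc3)o2)cc1`, gives 17600 nM.
Compound 3, `O=C(CSc1nnc(-c2ccncc2)o1)N/N=C/c1cccc(F)c1`, gives 24900 nM.

Compound 3 carries the highest of the three numbers; its nearest neighbour is compound 2, within the scatter, while compound 1 lies furthest away, beyond the scatter. Compound 4, `O=C(CSc1nnc(-c2ccncc2)o1)N/N=C/c1cc(Cl)cc(Cl)c1O`, differs from compound 3 in one place: 3,5-dichloro-2-hydroxyphenyl in place of 3-fluorophenyl on a carbon with a double bond to nitrogen. The step that bears most directly on this change is a 2.1-fold higher number from compound 1 to compound 3 (0.33 log units; beyond the scatter), where the hydroxyl-bearing aryl had the lower number; by contrast a 1.4-fold higher number from compound 2 to compound 3 (0.15 log units; within the scatter) and a 1.5-fold higher number from compound 1 to compound 2 (0.18 log units; within the scatter) stayed within the scatter. Within the data shown here, no measured step introduces chlorine onto this aryl, so the weight of the two chlorines is unknown. Because compound 1 sits at 11700 nM while compound 3 sits at 24900 nM, a modest move toward lower numbers in this assay seems more likely than a rise. Compound 4 is therefore expected to give about 12000 nM, with a range from 4000 nM to 35000 nM. For compound 4 this amounts to an expected 2.1-fold lower number from compound 3 to compound 4 (0.32 log units; beyond the scatter).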

Compound 4, half-maximal inhibitory concentration: 5920 nM
Estimate against measurement, compound 4: 2.0-fold (0.31 log units) above, within the range that was stated.
By their numbers in this assay, from the lowest: compounds 4, 1, 2 and 3 (each within the scatter of the next, the first and the last beyond it).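

In this assay, 3,5-dichloro-2-hydroxyphenyl on the carbon with a double bond to nitrogen gives a 4.2-fold lower number from compound 3 to compound 4 (0.62 log units; beyond the scatter) and a 3.0-fold lower number from compound 2 to compound 4 (0.47 log units; beyond the scatter) as well, so this position accepts the two chlorines together with a hydroxyl and moves clearly away from both the 3-fluorophenyl and the 4-methoxyphenyl compounds. Against the 4-hydroxyphenyl aryl the same change gives a 2.0-fold lower number from compound 1 to compound 4 (0.30 log units; within the scatter) and no more, which leaves compound 1 and compound 4 unseparated and shows no gain from this aryl over the simpler hydroxyl-bearing one. No measurement at hand explains any of these steps.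

It remains open whether the chlorines or the hydroxyl of this aryl carry the step from the 3-fluorophenyl compound, as the two are not separated in the compounds shown. Also open, as far as these compounds go, is how an amine, a carboxylic acid or a bromine on this aryl would read in this assay against the core of compound 1.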